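The source may report more compounds than this note shows. Statements on the series, on what has been measured and on what is new or still open speak of the compounds shown alone.

Compound 1 `O=[N+]([O-])c1cc(CSc2nnc(-c3ccc(Cl)cc3)n2Cc2ccccc2)cc([N+](=O)[O-])c1` and compound 2 `O=[N+]([O-])c1cc(CSc2nnc(-c3ccc(Br)cc3)n2Cc2ccccc2)cc([N+](=O)[O-])c1` carry one core, compound 3 `Cn1c(SCc2ccc(Br)cc2)nnc1-c1cc([N+](=O)[O-])cc([N+](=O)[O-])c1` and compound 4 `Cn1c(SCc2ccc(Cl)cc2)nnc1-c1cc([N+](=O)[O-])cc([N+](=O)[O-])c1` another; how the core of compound 2 differs from the core of compound 3 is not broken down here.

In an ADME assay on HepG2 cells (Homo sapiens) for cytotoxicity, with a stated time of 48 h (on this read-out lower numbers stand for stronger inhibition and higher numbers for weaker inhibition), compound 1 gives a limit of the assay, > 30000 nM. In this assay compound 2 also gives a limit, > 30000 nM. In this assay compound 3 likewise gives a limit, > 30000 nM.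

Compound 2 and compound 1 differ by chloro in place of bromo on an aromatic carbon. The step that the two limits leave unreadable from compound 2 to compound 1 has no readable size because the limit of > 30000 nM in this assay, at which 3 of the 3 values shown sit, covers both of its ends, so the change cannot be said to help or to hurt in this assay.

Compound 3 and compound 4 differ by chloro in place of bromo on an aromatic carbon. The place is the same word for word as in the pair of compound 2 and compound 1, so this is the same change, on a different core. Against the measured pair the step from compound 3 to compound 4 in this assay is expected to be a step that the limit leaves unreadable from compound 3 to compound 4, which rests on the limit of > 30000 nM in this assay, at which 3 of the 3 values shown sit, and on compound 3 sitting at that limit with > 30000 nM. The expected value for compound 4 in this assay is 60000 nM, between 25000 nM and 200000 nM, with the read-out most likely again only a limit.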

Compound 4, half-maximal inhibitory concentration: > 30000 nM
Compound 4: only a limit was reported (the forecaster's own chance of this, stated with the estimate: 88%); the middle value is on the limit's open side.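

No step can be read from compound 3 to compound 4 in this assay, because both compounds give only a limit: the limit of > 30000 nM in this assay, at which 4 of the 4 values shown sit.

The compounds shown leave open whether chloro in place of bromo on an aromatic carbon changes the read-out in this assay on either core, and what actual value any of the four compounds has past that limit.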